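From a free hydroxyl to its acetate on a shared core

The compounds below may be only part of what the source reports. "The series", "measured", "known", "first", "only" and "open" are said of these compounds alone.

Compound 1, `C[C@@H]1CC=C2C(C)(C)CCC[C@]2(C)[C@@]1(O)CCC1=CC(=O)OC1`, is reported in a functional assay on HL-60 cells (Homo sapiens) for cytotoxicity, read by MTT assay, with a stated time of 72 h (on this read-out higher numbers stand for weaker inhibition and lower numbers for stronger inhibition), only as a limit, < 5 ug/mL. Compound 2, `CC(=O)O[C@@H]1C[C@@H](C)[C@](O)(CCc2ccoc2)[C@@]2(C)CCCC(C)(C)[C@H]12`, is likewise reported in this assay only as a limit, < 5 ug/mL. Compound 3, `C[C@@H]1C[C@@H](O)[C@H]2C(C)(C)CCC[C@]2(C)[C@@]12CC[C@]1(COC(=O)C1)O2`, again gives in this assay only a limit, < 5 ug/mL.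

So compound 3 stands where every measured compound here stands: at the limit of < 5 ug/mL in this assay, at which 3 of the 3 values shown sit. Among the measured compounds shown here, no true number is known for any of them, and no step between two measured compounds can be read off, since all three values are limits rather than numbers.

Compound 4, `CC(=O)O[C@@H]1C[C@@H](C)[C@]2(CC[C@]3(COC(=O)C3)O2)[C@@]2(C)CCCC(C)(C)[C@H]12`, is the next compound in line. It differs from compound 3 by one change, (acetyl in place of hydrogen on an oxygen on a saturated carbon). Because all three measured compounds sit at the limit of < 5 ug/mL in this assay, at which 3 of the 3 values shown sit, the evidence gives no direction for this change. The expected step from compound 3 to compound 4 in this assay is therefore none beyond the scatter, a step that the limit leaves unreadable from compound 3 to compound 4. For compound 4 the estimated value in this assay is 2 ug/mL, with an expected range from 0.5 ug/mL to 8 ug/mL, and most likely the assay would again report only a limit for compound 4.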

Compound 4, half-maximal inhibitory concentration: < 5 ug/mL
Compound 4 was reported as a limit; the forecaster's own chance of this, stated with the estimate: 70%; the middle value lies beyond the limit too.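

Compound 3 and compound 4 are both reported in this assay only as limits, so no step can be read from one to the other. The compounds shown leave open how strong each one truly is, and whether hydroxy to acetoxy changes anything, as all the values share one limit: the limit of < 5 ug/mL in this assay, at which 4 of the 4 values shown sit.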